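The compounds below may be only part of what the source reports. "The series", "measured", "known", "first", "only" and "open" are said of these compounds alone.

Compound 1 `CNC(=O)c1cc(Oc2ccc(NC(=O)c3cc(-c4ccc(Cl)cc4)ncn3)cc2)ccn1` — > 100000 nM
Compound 2 `CNC(=O)c1cc(Oc2ccc(NC(=O)c3cc(-c4ccc(OC)cc4)ncn3)cc2F)ccn1` — 46200 nM
Compound 3 `CNC(=O)c1cc(Oc2ccc(NC(=O)c3nccc(-c4ccc(OC)cc4)n3)cc2F)ccn1` — > 100000 nM

In a functional assay on MCF7 cells (Homo sapiens) for cytotoxicity, read by MTT assay, with a stated time of 72 h (on this read-out lower numbers stand for stronger inhibition and higher numbers for weaker inhibition), compound 2 gives 46200 nM, and this is the only numerical result among the three compounds. Compound 1 returns no number but only a limit of the assay, > 100000 nM. Compound 3 likewise returns only a limit, > 100000 nM. Among the compounds with values here, two of the three results therefore rest at the limit of > 100000 nM in this assay, at which 2 of the 3 values shown sit, so compound 2 stands alone as the single measured value, and no step between measured compounds can be computed from these data.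

Compound 4 `CNC(=O)c1cc(Oc2ccc(NC(=O)c3cc(-c4ccc(Br)cc4)ncn3)cc2F)ccn1` differs from compound 2 in one place: bromo in place of methoxy on an aromatic carbon. Compound 1, which carries a halogen rather than a methoxy group on that ring, gives only a limit, > 100000 nM. On that ground the exchange is expected to shift inhibition toward the weaker side by a 1.9-fold higher number from compound 2 to compound 4 (0.29 log units; within the scatter), a step beyond the usual scatter rather than within it. Compound 4 is accordingly estimated at 90000 nM, with a range from 35000 nM to 250000 nM, and with a fair chance that this assay reports only a limit instead of a number.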

Compound 4, half-maximal inhibitory concentration: > 100000 nM
Compound 4: a limit, no number (the forecaster's own chance of this, stated with the estimate: 45%); middle value at least 1.1-fold (0.04 log units) away from the limit.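

Bromo in place of methoxy on this aromatic carbon, para to a large group, gives in this assay an at least 2.1-fold higher number from compound 2 to compound 4 (0.33 log units; beyond the scatter), and this single exchange removes the only measured number in the series. The earlier compounds shown here could not isolate this position: compound 1 also carries a halogen on that ring, but it differs from compound 2 in more than one place, whereas the change from 4-methoxyphenyl to 4-bromophenyl is the only difference here. The step is only a lower bound and its full size cannot be read, because compound 4 returns a limit rather than a number, as most of the series does: the limit of > 100000 nM in this assay, at which 3 of the 4 values shown sit.

The compounds shown leave open whether methoxy is unusual at this carbon or whether other small groups, such as a hydroxyl, an amine or a methyl, would also give a measurable number. They also leave open whether a longer ether such as ethoxy would keep that number or fall to the same limit.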